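The compounds below may be only part of what the source reports. "The series", "measured", "known", "first", "only" and "open" are said of these compounds alone.

Measured in a functional assay on HeLa cells (Homo sapiens) for cytotoxicity, read by neutral red uptake, with a stated time of 3 days; on this read-out higher numbers stand for weaker inhibition and lower numbers for stronger inhibition:
- compound 1 `CCCCCCc1c(F)c(N)c2c(=O)cc(-c3ccc(N)c(F)c3)oc2c1F` gives 21000 nM
- compound 2 `Nc1ccc(-c2cc(=O)c3c(N)c(F)c(Br)c(F)c3o2)cc1F` gives only a limit, > 100000 nM
- compound 3 `CCCCCC(=O)OCc1c(F)c(N)c2c(=O)cc(-c3ccc(N)c(F)c3)oc2c1F` gives 34000 nM

Compound 3 and compound 1 cannot be separated in this assay: a 1.6-fold higher number from compound 1 to compound 3 (0.21 log units; within the scatter). Compound 2 sits at the limit noted in the limit of > 100000 nM in this assay, at which 1 of the 3 values shown sits; against it, compound 1 shows an at least 4.7-fold higher number from compound 1 to compound 2 (0.67 log units; beyond the scatter) and compound 3 shows an at least 2.9-fold lower number from compound 2 to compound 3 (0.46 log units; beyond the scatter), both beyond the scatter.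

Compound 4 `CCCCCCOCc1c(F)c(N)c2c(=O)cc(-c3ccc(N)c(F)c3)oc2c1F` differs from compound 3 by hexyl in place of pentylcarbonyl on an oxygen on a saturated carbon. Among the measured compounds shown here, the one measured step that bears on this is the exchange of pentyl for (pentylcarbonyl)oxy from compound 1 to compound 3, which stayed within the scatter: a 1.6-fold higher number from compound 1 to compound 3 (0.21 log units; within the scatter). For the measured compounds named here, compound 4 keeps a saturated chain of similar length on the same oxygen and loses the carbonyl; no measured pair tests an ether here, so the expectation is a step of no more than the scatter in this assay, with no direction assigned: a 1.4-fold lower number from compound 3 to compound 4 (0.13 log units; within the scatter) is the expected change. Compound 4 is therefore estimated at 25000 nM, expected between 10000 nM and 65000 nM.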

Compound 4, half-maximal inhibitory concentration: > 100000 nM
Compound 4: a limit, no number; the forecaster's own chance of this, stated with the estimate: 10%; middle value at least 4.0-fold (0.60 log units) from the limit.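

In this assay compound 4 gives only a limit and no number, and it joins compound 2 there: the limit of > 100000 nM in this assay, at which 2 of the 4 values shown sit. Hexyl in place of pentylcarbonyl on this oxygen gives an at least 2.9-fold higher number from compound 3 to compound 4 (0.46 log units; beyond the scatter) and hexyloxy in place of pentyl gives an at least 4.7-fold higher number from compound 1 to compound 4 (0.67 log units; beyond the scatter) while the earlier exchange to (pentylcarbonyl)oxy gave only a 1.6-fold higher number from compound 1 to compound 3 (0.21 log units; within the scatter). This place on the saturated carbon therefore does not accept every chain of similar size: the ester compound 3 keeps a measurable number and the ether compound 4 does not.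

As far as these compounds go, the true size of both readable steps stays open, and the step between the two limit compounds cannot be read. Also open, from the compounds shown here alone, is whether the carbonyl itself matters here, which an amide, a free hydroxyl or a shorter ether chain at this place could test.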